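Carbamoyl for trifluoromethyl on the pendant phenyl

This account rests on a few compounds, and the source may have more. Where it says the series, first, only, none or still open, it means among the compounds named here.

Two compounds of the series carry the same core and differ only in the aryl group on it. Compound 1 `CCCS(=O)(=O)Nc1ccc(F)c(C(=O)c2n[nH]c3ncc(-c4cccc(N(C)C)c4)cc23)c1F` gives 26% in an assay for binding affinity to dual specificity mitogen-activated protein kinase kinase 4 (Homo sapiens), read by KINOMEscan, tested at 100 nM; a lower number here means a stronger effect, a higher number a weaker effect of the compound at the concentration tested. Compound 2 `CCCS(=O)(=O)Nc1ccc(F)c(C(=O)c2n[nH]c3ncc(-c4ccc(C(F)(F)F)cc4)cc23)c1F` gives 29% in this assay; this is the higher of the two numbers, but the step of a number 3 percentage points higher from compound 1 to compound 2 (within the scatter) is within the scatter, so the two aryl groups cannot be told apart on this basis. Compound 3 `CCCS(=O)(=O)Nc1ccc(F)c(C(=O)c2n[nH]c3ncc(-c4ccc(C(N)=O)cc4)cc23)c1F` is not yet measured; it differs from compound 2 by carbamoyl in place of trifluoromethyl on an aromatic carbon. Among the compounds with values here, the only step that bears on a change at this aryl group is a number 3 percentage points higher from compound 1 to compound 2 (within the scatter), and it was flat. Nothing in the data points to a direction for this change, so compound 3 is expected to move by about a number 4 percentage points higher from compound 2 to compound 3 (within the scatter), that is, to stay within the scatter of compound 2. The estimate for compound 3 in this assay is 33%, with a range from 14% to 60%.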

Compound 3, a percentage reported as activity, at one concentration (the size of the read-out at that concentration, not a potency): 0.15%
The estimate for compound 3 lay 32.9 percentage points above the measured number, outside the stated range (below it).
By their numbers in this assay, from the lowest: compound 3; then compounds 1 and 2 (each within the scatter of the next).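

The aryl position of the shared core is not flat in this assay: carbamoyl in place of trifluoromethyl gives a number 28.9 percentage points lower from compound 2 to compound 3 (beyond the scatter), whereas the earlier aryl swap gave only a number 3 percentage points higher from compound 1 to compound 2 (within the scatter). The 4-carbamoylphenyl group also separates from 3-(dimethylamino)phenyl, with a number 25.9 percentage points lower from compound 1 to compound 3 (beyond the scatter), so compound 3 has the strongest effect of the three at the concentration tested, and the aryl group can now be told apart on this read-out. No measurement at hand explains this drop.

From the compounds shown here alone, whether the effect is specific to carbamoyl remains open, as a carboxylic acid, a nitrile or an N-methylcarbamoyl group at the same place could show. Going by these compounds, a single-concentration read-out also gives no potency, so the size of the difference between these compounds in potency terms stays unknown.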